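This account rests on a few compounds, and the source may have more. Where it says the series, first, only, none or still open, it means among the compounds named here.

Measured compounds in a functional assay on HeLa cells (Homo sapiens) for cytotoxicity, read by sulforhodamine B assay, with a stated time of 72 h; on this read-out lower numbers stand for stronger inhibition and higher numbers for weaker inhibition:

- compound 1 `C=C1C(=O)O[C@@H]2CC(C)=C([C@@H](C)CCCOC(C)=O)[C@@H](OC(=O)CN3CCCC3)[C@H]12`: 12700 nM
- compound 2 `C=C1C(=O)O[C@@H]2CC(C)=C([C@@H](C)CCCOC(C)=O)[C@@H](OC(=O)c3ccccc3)[C@H]12`: 5190 nM
- compound 3 `C=C1C(=O)O[C@@H]2CC(C)=C([C@@H](C)CCCOC(C)=O)[C@@H](OC(=O)c3ccc(OC)cc3)[C@H]12`: 8850 nM

Compound 1 gives the highest of the three numbers in this assay. Its nearest neighbour is compound 3, a 1.4-fold lower number from compound 1 to compound 3 (0.16 log units; within the scatter), which stays within the scatter; its furthest is compound 2, a 2.4-fold lower number from compound 1 to compound 2 (0.39 log units; beyond the scatter), a modest step beyond the scatter. Between the two aryl esters, a 1.7-fold higher number from compound 2 to compound 3 (0.23 log units; within the scatter), so the two aromatic esters cannot be told apart on these numbers.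

Compound 4 `C=C1C(=O)O[C@@H]2CC(C)=C([C@@H](C)CCCOC(C)=O)[C@@H](OC(=O)c3cc(OC)c(OC)c(OC)c3)[C@H]12` has not yet been measured in this assay. It differs from compound 1 in one place: 3,4,5-trimethoxyphenyl in place of (pyrrolidin-1-yl)methyl on a carbonyl carbon

Among the measured compounds shown here, the steps that bear on this change are those from the (pyrrolidin-1-yl)methyl ester to an aromatic ester, compound 1 to compound 2 and compound 1 to compound 3. Both go toward lower numbers, one beyond the scatter and one within it. Adding a methoxy on the aromatic carbon, compound 2 to compound 3, stayed within the scatter. A 3,4,5-trimethoxyphenyl ester is therefore expected to land near the other aryl esters, which means a small step toward a lower number, a 1.8-fold lower number from compound 1 to compound 4 (0.26 log units; within the scatter), with a real chance that it stays within the scatter.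

For compound 4 the expected value in this assay is 7000 nM, with a range of 3000 nM to 18000 nM.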

Compound 4, half-maximal inhibitory concentration: 6540 nM
The estimate for compound 4 lay 1.1-fold (0.03 log units) above the measured number; the range from low to high includes it.
By their numbers in this assay, from the lowest: compounds 2, 4, 3 and 1 (each within the scatter of the next, the first and the last beyond it).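

In this assay, the 3,4,5-trimethoxyphenyl ester gives a 1.9-fold lower number from compound 1 to compound 4 (0.29 log units; within the scatter), so this change, like the 4-methoxyphenyl one, does not separate from the (pyrrolidin-1-yl)methyl ester, and only the phenyl ester of compound 2 does so among the aryl esters shown. The aromatic ring on this carbonyl carbon now carries no, one or three methoxy groups without a readable change, with a 1.4-fold lower number from compound 3 to compound 4 (0.13 log units; within the scatter) and a 1.3-fold higher number from compound 2 to compound 4 (0.10 log units; within the scatter), so compounds 2, 3 and 4 form one group on these numbers and the added methoxy groups neither clearly help nor clearly harm. No supporting data on mechanism or on any property of these esters accompany the numbers, so these steps stay descriptive.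

The compounds shown leave open whether a simple aliphatic acyl group such as acetyl, or an aminoacetyl group with a morpholine or a dimethylamine in place of the pyrrolidine, would fall with compound 1 or with the aryl esters. Also open, from the compounds shown here alone, is whether a ring bearing a fluorine, a nitrile or a carboxylic acid in place of methoxy would move the number beyond the scatter of compound 2.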